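A Halogen Swap at an Assay Limit

A few compounds are considered here, and "the series" means these few. Any claim that something is new, unique, unknown or untested is made for them only; others in the source may bear on it.

In an ADME assay on microsomes from liver (Canis lupus familiaris) for metabolic stability (a lower number here means that the compound disappears faster, a higher number that the compound lasts longer), compound 1 (`N#Cc1ccc(-c2nc(NCCNc3ccc([N+](=O)[O-])c(N)n3)ncc2-c2ncc[nH]2)cc1`) gives > 0.5 h, which is a limit and not a number. Compound 2 (`Nc1nc(NCCNc2ncc(-c3ncc[nH]3)c(-c3ccc(Br)cc3F)n2)ccc1[N+](=O)[O-]`) gives > 0.5 h, which is also a limit, so it stands only within a range. The measured evidence comes down to the limit of > 0.5 h in this assay, at which 2 of the 2 values shown sit. Among the measured compounds shown here, the one measured step, a step that the two limits leave unreadable from compound 1 to compound 2, has no readable size, so it offers no size to carry forward. Compound 3 (`Nc1nc(NCCNc2ncc(-c3ncc[nH]3)c(-c3ccc(Cl)cc3Br)n2)ccc1[N+](=O)[O-]`) has 2-bromo-4-chlorophenyl in place of 4-bromo-2-fluorophenyl on an aromatic carbon, next to the ring nitrogen and ortho to a 1H-imidazol-2-yl group: 2-bromo-4-chlorophenyl in place of 4-bromo-2-fluorophenyl on an aromatic carbon. No shift beyond the usual scatter is expected in this assay. The expected change is a step that the limit leaves unreadable from compound 2 to compound 3. For compound 3 the estimate is 0.6 h, with an expected range from 0.3 h to 1.2 h.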

Compound 3, half-life: > 0.5 h
Compound 3: a limit, no number; the forecaster's own chance of this, stated with the estimate: 70%; the middle value does not contradict the limit.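

In this assay compound 3 gives > 0.5 h, a limit and not a number, so its steps from compound 1 and compound 2 cannot be read: the limit of > 0.5 h in this assay, at which 3 of the 3 values shown sit.

The compounds shown leave open how long compound 1, compound 2 and compound 3 actually last, and whether exchanging the substituted phenyl group changes that at all.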